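The source may report more compounds than this note shows. Statements on the series, on what has been measured and on what is new or still open speak of the compounds shown alone.

Compound 1 `O=C(OCCO)C1CCCCN1S(=O)(=O)Cc1ccccc1`: > 100000 nM
Compound 2 `O=C(OCCCc1cccnc1)C1CCCCN1S(=O)(=O)Cc1cccc([N+](=O)[O-])c1`: 46700 nM

Among the measured compounds shown here, in a toxicity assay (J774.1 cells) for cytotoxicity, with Mus musculus as the target, read by resazurin assay, with a stated time of 24 h (a higher number here means a weaker inhibitor, a lower number a stronger inhibitor), compound 2 gives 46700 nM, the only actual number so far. Compound 1 reads > 100000 nM, which is a limit of the assay and not a number.

Compound 3 `Nc1cccc(CS(=O)(=O)N2CCCCC2C(=O)OCCCc2cccnc2)c1` follows from compound 2 by amino in place of nitro on an aromatic carbon, 3-nitrobenzyl to 3-aminobenzyl (amino in place of nitro on an aromatic carbon). For the measured compounds named here, no measured pair shows this change, so the only anchor is compound 2 at 46700 nM, and no shift beyond the scatter is expected in this assay. The expected 1.3-fold higher number from compound 2 to compound 3 (0.11 log units; within the scatter) is small. For compound 3 the estimate is 60000 nM, with an expected range of 25000 nM to 100000 nM.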

Compound 3, half-maximal inhibitory concentration: 62300 nM
Beside the measured number, compound 3's estimate is 1.0-fold (0.02 log units) below it; the range from low to high includes it.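

Amino in place of nitro on an aromatic carbon gives a 1.3-fold higher number from compound 2 to compound 3 (0.13 log units; within the scatter) in this assay. This first measured step in the series shows that, at this place on the benzyl ring, trading nitro, with 0 hydrogen-bond donors, for amino, with 1 hydrogen-bond donor, moves the number no further than the scatter. Readings in this assay also end at a limit: the limit of > 100000 nM in this assay, at which 1 of the 3 values shown sits.

Still open, from the compounds shown here alone, is whether a carboxylic acid or an acetamide at this place would behave like nitro and amino. Also open, going by these compounds, is whether a longer chain in the ester would shift the number beyond the scatter.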